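The source may report more compounds than this note shows. Statements on the series, on what has been measured and on what is new or still open speak of the compounds shown alone.

Working notes on the series. Compound 1 `COc1cc(OC)c(OC)cc1/C=C/C(=O)c1ccc(C)cc1` carries a methyl on its second aromatic ring, while compound 2 `COc1cc(OC)c(OC)cc1/C=C/C(=O)c1cc(Cc2ccccc2)cc(Cc2ccccc2)c1` carries two benzyl groups there instead. In a functional assay on MCF7 cells (Homo sapiens) for inhibition, read by MTT assay, with a stated time of 72 h (on this read-out lower numbers stand for stronger inhibition and higher numbers for weaker inhibition), compound 1 gives 33000 nM, the highest of the two numbers recorded so far; in this assay compound 2 gives 23300 nM, and the gap between the two lies within the scatter, so no order between them can be read.

Compound 3 `COc1cc(OC)c(OC)cc1/C=C/C(=O)c1ccc(O)cc1` is not yet measured. It differs from compound 1 by hydroxy in place of methyl on an aromatic carbon. Among the compounds with values here, no step between measured compounds has been recorded for this kind of change, so nothing in the data pins its size. The expectation is a small step in the direction of a lower number, a 1.7-fold lower number from compound 1 to compound 3 (0.22 log units; within the scatter), with a range wide enough that no change beyond the scatter is also plausible. Compound 3 is therefore expected to give about 20000 nM in this assay, between 6000 nM and 65000 nM.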

Compound 3, half-maximal inhibitory concentration: 182000 nM
Compound 3: the middle estimate sits 9.1-fold (0.96 log units) below what was measured; measured number outside the range, above it.
By their numbers in this assay, from the lowest: compounds 2 and 1 (each within the scatter of the next); then compound 3.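

Within the data shown here, the change from 4-methylphenyl to 4-hydroxyphenyl is the only step so far that lies beyond the scatter: in this assay it gives a 5.5-fold higher number from compound 1 to compound 3 (0.74 log units; beyond the scatter) and so moves towards weaker inhibition. This place on the ring is therefore not indifferent to what it carries, since exchanging a single heavy atom, with one hydrogen-bond donor and one hydrogen-bond acceptor entering, is enough to produce a clear step. Nothing at hand accounts for the direction or size of this step.

From the compounds shown here alone, whether the step belongs to hydroxy alone remains open, and a methoxy group, an amine or a carboxylic acid at the same place would test this. Going by these compounds, it is also open whether the same exchange would give a similar step with the two benzyl groups of compound 2 on the ring.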